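A Fluoro Step Repeated on a Different Ring

The source may hold more compounds than are shown below. What is called first, only, known or untested is meant among the compounds shown, and "the series" means these compounds.

Compound 1 `O=C(Nc1ccc(Oc2ccnc3[nH]ccc23)cc1)c1cn(-c2ccccc2)c2ccccc2c1=O` was tested in a functional assay on MCF7 cells (Homo sapiens) for inhibition, read by MTT assay, with a stated time of 72 h (a lower number here means a stronger inhibitor, a higher number a weaker inhibitor), where compound 1 gives 3560 nM. Compound 2 `O=C(Nc1ccc(Oc2ccnc3[nH]ccc23)cc1)c1cn(-c2ccc(F)cc2)c2ccccc2c1=O` carries fluoro in place of hydrogen on an aromatic carbon and in this assay compound 2 gives 720 nM, a step of a 4.9-fold lower number from compound 1 to compound 2 (0.69 log units; beyond the scatter). Compound 3 `Cn1ccc2c(Oc3ccc(NC(=O)c4cn(-c5ccc(Br)cc5)c5ccccc5c4=O)cc3F)ccnc21` rests on another core; the difference between the core of compound 3 and that of compound 1 is not broken down here. In this assay compound 3 gives 1830 nM. Compound 4 `Cn1ccc2c(Oc3ccc(NC(=O)c4cn(-c5ccc(Br)cc5F)c5ccccc5c4=O)cc3F)ccnc21` is not yet measured and differs from compound 3 by fluoro in place of hydrogen on an aromatic carbon. This is the same kind of change as that from compound 1 to compound 2, but here the fluoro sits ortho to a large group and meta to a bromo group rather than para to a large group. Because the earlier step was a 4.9-fold lower number from compound 1 to compound 2 (0.69 log units; beyond the scatter), a lower number is expected for compound 4. Given the changed place, a smaller step of a 1.5-fold lower number from compound 3 to compound 4 (0.18 log units; within the scatter) is estimated for compound 4. Compound 4 is expected to give about 1200 nM in this assay, likely between 400 nM and 3500 nM.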

Compound 4, half-maximal inhibitory concentration: 420 nM
Compound 4: the middle estimate sits 2.9-fold (0.46 log units) above what was measured; the range from low to high includes it.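

In this assay the fluoro change gave a 4.4-fold lower number from compound 3 to compound 4 (0.64 log units; beyond the scatter) and so kept much the same size when carried from one core to the other: the same change on two cores in this assay, a 4.9-fold lower number (0.69 log units; beyond the scatter) from compound 1 to compound 2 and a 4.4-fold lower number (0.64 log units; beyond the scatter) from compound 3 to compound 4, 1.1-fold (0.05 log units) apart, within the scatter of two such steps.

Within the data shown here, this agreement rests on only two pairs, and they differ in the place of the fluoro as well as in the core, so the two influences cannot be told apart. It does not show that the change would hold on any further core, and it gives no reason for the lower numbers.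

The compounds shown leave open whether fluoro in the place it holds in compound 4 would give a like step on the core of compound 1. They also leave open whether chloro, methyl or methoxy in that place would do the same.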